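Phenyl in Place of Chloro in a Flat Series

The source may hold more compounds than are shown below. What is called first, only, known or untested is meant among the compounds shown, and "the series" means these compounds.

In a functional assay on NB-4 cells (Homo sapiens) for cytotoxicity, read by CCK-8 assay, with a stated time of 24 h (a higher number here means a weaker inhibitor, a lower number a stronger inhibitor), three compounds sharing one core have been measured. Compound 1 `C=CC(=O)N1C(=O)CC(c2ccc(C(F)(F)F)cc2)Sc2ccccc21` gives 38600 nM, compound 2 `C=CC(=O)N1C(=O)CC(c2ccc(C)cc2)Sc2ccccc21` gives 37300 nM, and compound 3 `C=CC(=O)N1C(=O)CC(c2ccc(Cl)cc2)Sc2ccccc21` gives 22600 nM. Compound 3 therefore stands within the scatter of both other compounds, and the numbers do not separate the three.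

Compound 4 `C=CC(=O)N1C(=O)CC(c2ccc(-c3ccccc3)cc2)Sc2ccccc21` has phenyl in place of chloro on an aromatic carbon, para to a large group: phenyl in place of chloro on an aromatic carbon. Among the compounds with values here, three measured steps bear on this change: a 1.0-fold lower number from compound 1 to compound 2 (0.01 log units; within the scatter), a 1.7-fold lower number from compound 1 to compound 3 (0.23 log units; within the scatter) and a 1.7-fold lower number from compound 2 to compound 3 (0.22 log units; within the scatter). Each lies within the scatter. None of them brings in a ring, however, so they guide this larger change only loosely, and the range must stay wide. No shift beyond the scatter is expected in this assay, and no direction is favoured. The expected step is a 1.2-fold higher number from compound 3 to compound 4 (0.09 log units; within the scatter). Compound 4 is estimated at 28000 nM, with an expected range from 11000 nM to 65000 nM.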

Compound 4, half-maximal inhibitory concentration: 57700 nM
Compound 4: the middle estimate sits 2.1-fold (0.31 log units) below what was measured; low and high end bracket the measured number.
By their numbers in this assay, from the lowest: compounds 3, 2, 1 and 4 (each within the scatter of the next, the first and the last beyond it).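

In this assay, this aromatic carbon now gives its first step beyond the scatter, a 2.6-fold higher number from compound 3 to compound 4 (0.41 log units; beyond the scatter), so the series is no longer wholly flat at this position, though the separation is modest. It holds against chloro alone: the steps of a 1.5-fold higher number from compound 2 to compound 4 (0.19 log units; within the scatter) and a 1.5-fold higher number from compound 1 to compound 4 (0.17 log units; within the scatter) both lie within the scatter, so phenyl is not set apart from methyl or trifluoromethyl. Nothing measured here accounts for the step from chloro to phenyl.

The compounds shown leave open how an amine, a carboxylic acid or a saturated cyclohexyl ring would stand on this carbon, and so whether an aromatic ring as such matters here. They also leave open whether the same step would appear with a pyridine ring in place of phenyl.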